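The source may hold more compounds than are shown below. What is called first, only, known or untested is meant among the compounds shown, and "the series" means these compounds.

Working notes on the series in a functional assay on HepG2 cells (Homo sapiens) for cytotoxicity, read by MTT assay, with a stated time of 72 h; on this read-out lower numbers stand for stronger inhibition and higher numbers for weaker inhibition. Compound 1 `COc1ccc(-n2ccc(=O)c(C(=O)Nc3ccc(Oc4ccnc5[nH]ccc45)c(F)c3)n2)cc1` gives only a limit of the assay, > 60000 nM. Compound 2 `Cc1cc(=O)n(-c2ccccc2OC(F)(F)F)nc1C(=O)Nc1ccc(Oc2ncnc3[nH]ccc23)cc1` gives 22800 nM. Compound 3 `Cc1cc(=O)n(-c2ccccc2OC(F)(F)F)nc1C(=O)Nc1ccc(Oc2ncnc3c2ccn3C)cc1` likewise gives only a limit, > 60000 nM. Among the measured compounds shown here, the sole measured step, an at least 2.6-fold higher number from compound 2 to compound 3 (0.42 log units; beyond the scatter), runs up into (the limit of > 60000 nM in this assay, at which 2 of the 3 values shown sit), so compound 3 stands at the top edge of what this assay reports. Compound 4 `Cc1cc(=O)n(-c2ccccc2Cl)nc1C(=O)Nc1ccc(Oc2ncnc3c2ccn3C)cc1` differs from compound 3 by chloro in place of trifluoromethoxy on an aromatic carbon. For the measured compounds named here, no measured step touches this exchange; the one step known concerns another part of the molecule and offers no guide. With compound 3 already at the limit, compound 4 is expected to remain there, the estimated step of a number no higher from compound 3 to compound 4 (the limit leaves the size open) amounting to no change beyond the scatter. The estimate for compound 4 is 60000 nM, between 30000 nM and 120000 nM.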

Compound 4, half-maximal inhibitory concentration: 11200 nM
For compound 4 the middle estimate is 5.4-fold (0.73 log units) above the measured one; measured number below the stated range.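

In this assay, 2-(trifluoromethoxy)phenyl to 2-chlorophenyl gives an at least 5.3-fold lower number from compound 3 to compound 4 (0.72 log units; beyond the scatter), so this place on the six-membered aromatic ring of carbon only changes the read-out, and the change moves the series off the top edge of the assay. The earlier step concerned an aromatic nitrogen and said nothing about this place. The true size of the step stays open because compound 3 gives only a limit: the limit of > 60000 nM in this assay, at which 2 of the 4 values shown sit.

As far as these compounds go, it also remains open whether the exchange reads the same with hydrogen in place of methyl on that aromatic nitrogen, and how a fluoro, a methyl or an amine would compare at this place.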